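The source may report more compounds than this note shows. Statements on the series, on what has been measured and on what is new or still open speak of the compounds shown alone.

Of the compounds shown here, two that share one core have been measured so far in a functional assay on A549 cells (Homo sapiens) for cytotoxicity, read by MTT assay, with a stated time of 72 h; on this read-out higher numbers stand for weaker inhibition and lower numbers for stronger inhibition. Compound 1 `COc1ccc(/C=C2\CCC/C(=C\c3ccc(Br)cc3)C2=O)cc1OC`, which carries a 4-bromophenyl group, gives 16000 nM. Compound 2 `COc1ccc(/C=C2\CCC/C(=C\c3ccc(Cl)c(Cl)c3)C2=O)cc1OC`, which carries a 3,4-dichlorophenyl group there instead, gives 6900 nM, the lower of the two numbers.

Compound 3 `COc1ccc(/C=C2\CCC/C(=C\c3ccc(O)c(Cl)c3)C2=O)cc1OC` changes the same part of the molecule: hydroxy in place of chloro on an aromatic carbon. This puts hydroxy in place of chloro on an aromatic carbon, ortho to a chloro group and para to a large group, so 3,4-dichlorophenyl becomes 3-chloro-4-hydroxyphenyl.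

Among the measured compounds shown here, only one measured step bears on this change: a 2.3-fold lower number from compound 1 to compound 2 (0.37 log units; beyond the scatter). It was modest and involved the same group, but it exchanged only halogens. Neither measured compound carries a hydroxy group, so that step gives no firm direction for this swap. In this assay, for the measured compounds named here, no step clearly beyond the scatter is therefore expected, although a modest move either way remains possible. The expected change is a 1.3-fold lower number from compound 2 to compound 3 (0.10 log units; within the scatter). For compound 3, the estimated value is 5500 nM, with an expected range from 1800 nM to 16000 nM.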

Compound 3, half-maximal inhibitory concentration: > 20000 nM
Compound 3 gave a limit, no number (the forecaster's own chance of this, stated with the estimate: 5%); middle value at least 3.6-fold (0.56 log units) away from the limit.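

The reading for compound 3 in this assay is a limit of the assay and not a number: the limit of > 20000 nM in this assay, at which 1 of the 3 values shown sits. Even so, hydroxy in place of chloro gives an at least 2.8-fold higher number from compound 2 to compound 3 (0.46 log units; beyond the scatter), which shows that this aromatic carbon, para to a large group, is not indifferent to what it carries, and that in this pair the hydroxy group goes with weaker inhibition, a direction the two halogen-bearing compounds could not reveal. The wider comparison gives an at least 1.2-fold higher number from compound 1 to compound 3 (0.09 log units; that floor lies within the scatter), so those two compounds are not firmly separated.

From the compounds shown here alone, what stays open is how much weaker compound 3 really is, and whether the shift follows from the arrival of the hydroxy group or from the departure of the chloro group. The compounds shown also do not tell whether a methoxy group or an amine on this carbon would behave more like hydroxy or more like chloro.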